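Longer Acyl Chains on a Shared Core

A few compounds are considered here, and "the series" means these few. Any claim that something is new, unique, unknown or untested is made for them only; others in the source may bear on it.

Three compounds sharing one core differ only in the length of the saturated chain attached to the carbonyl carbon. Compound 1 `CC(=O)Nc1ccn([C@@H]2CO[C@H](CO)O2)c(=O)n1` gives 6870 nM in a functional assay on A549 cells (Homo sapiens) for cytotoxicity, read by sulforhodamine B assay, with a stated time of 72 h; on this read-out higher numbers stand for weaker inhibition and lower numbers for stronger inhibition. Compound 2 `CCCC(=O)Nc1ccn([C@@H]2CO[C@H](CO)O2)c(=O)n1` gives 6600 nM in this assay, and compound 3 `CCCCC(=O)Nc1ccn([C@@H]2CO[C@H](CO)O2)c(=O)n1` gives 5230 nM. Compound 3 has the lowest of the three numbers, yet every step toward it is within the scatter: a 1.0-fold lower number from compound 1 to compound 2 (0.02 log units; within the scatter), a 1.3-fold lower number from compound 1 to compound 3 (0.12 log units; within the scatter) and a 1.3-fold lower number from compound 2 to compound 3 (0.10 log units; within the scatter).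

Compound 4 `CCCCCCC(=O)Nc1ccn([C@@H]2CO[C@H](CO)O2)c(=O)n1` carries the same chain one stage longer: ethyl in place of hydrogen on a saturated chain carbon, four bonds along the chain from a carbonyl carbon. All three measured steps are chain extensions of this kind and none of them moved the number beyond the scatter, so the step into compound 4 is expected to be flat as well, or at most a slight drift toward a lower number, as the estimate a 1.2-fold lower number from compound 3 to compound 4 (0.07 log units; within the scatter) in this assay means. Compound 4 is therefore estimated at 4500 nM in this assay, with a range from 2000 nM to 10000 nM.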

Compound 4, half-maximal inhibitory concentration: 1040 nM
Compound 4: the middle estimate sits 4.3-fold (0.64 log units) above what was measured; the whole stated range lies above it.
By their numbers in this assay, from the lowest: compound 4; then compounds 3, 2 and 1 (each within the scatter of the next).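

Ethyl in place of hydrogen on a saturated chain carbon, four bonds along the chain from a carbonyl carbon, is the first change in this series to go beyond the scatter in this assay (a 5.0-fold lower number from compound 3 to compound 4 (0.70 log units; beyond the scatter)), and the longer steps into compound 4 do so too (a 6.3-fold lower number from compound 2 to compound 4 (0.80 log units; beyond the scatter) and a 6.6-fold lower number from compound 1 to compound 4 (0.82 log units; beyond the scatter)). Lengthening the chain therefore does not act evenly, since the same ethyl change on the shorter chain left the number flat: the same change on two cores in this assay, a 1.0-fold lower number (0.02 log units; within the scatter) from compound 1 to compound 2 and a 5.0-fold lower number (0.70 log units; beyond the scatter) from compound 3 to compound 4, 4.8-fold (0.68 log units) apart, beyond the scatter of two such steps. The propyl change shows the same dependence on the chain it extends: the same change on two cores in this assay, a 1.3-fold lower number (0.12 log units; within the scatter) from compound 1 to compound 3 and a 6.3-fold lower number (0.80 log units; beyond the scatter) from compound 2 to compound 4, 4.8-fold (0.68 log units) apart, beyond the scatter of two such steps.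

On these data alone, whether a still longer chain would lower the number further or whether the drop ends at compound 4 remains open. Also open, as far as these compounds go, is how a branched chain, a phenyl group or an amine at the chain end would compare.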